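Methyl for Hydrogen on the Aryl Ring of Compound 2

The compounds below may be only part of what the source reports. "The series", "measured", "known", "first", "only" and "open" are said of these compounds alone.

Measured compounds:
compound 1, `COc1ccccc1-n1c(Nc2nc(-c3ccc([N+](=O)[O-])cc3)cs2)n[nH]c1=S`, 100 mg/kg
compound 2, `O=[N+]([O-])c1ccc(-c2csc(Nc3n[nH]c(=S)n3-c3ccccc3)n2)cc1`, 300 mg/kg
compound 3, `COc1ccc(-n2c(Nc3nc(-c4ccccc4)cs3)n[nH]c2=S)cc1`, 100 mg/kg

In a functional assay on the whole organism (strain Swiss albino) for inhibition, with Mus musculus as the target, with a stated time of 4 h (on this read-out lower numbers stand for an effect already at smaller amounts and higher numbers for an effect only at larger amounts of compound), compound 2 gives the highest number of the three; compound 1 and compound 3 sit beside it, each a step below that lies beyond the scatter. Compound 4, `Cc1ccccc1-n1c(Nc2nc(-c3ccc([N+](=O)[O-])cc3)cs2)n[nH]c1=S`, is the next compound, not yet measured. It differs from compound 2 in a single place: methyl in place of hydrogen on an aromatic carbon. The site is the same aromatic carbon at which compound 1 and compound 2 differ, where compound 1 carries a methoxy group. That one measured step bears on the present case: a 3.0-fold higher number from compound 1 to compound 2 (0.48 log units; beyond the scatter). Taking the hydrogen away from that carbon and putting a methoxy group there gave a lower number, so a methyl group at the same carbon is expected to move the number in the same direction, by a step of roughly similar size, though with the single precedent the size is uncertain. Compound 4 is therefore estimated at 150 mg/kg, within 75 mg/kg to 300 mg/kg, that is, an expected 2.0-fold lower number from compound 2 to compound 4 (0.30 log units; within the scatter).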

Compound 4, minimum effective dose: 100 mg/kg
Estimate against measurement, compound 4: 1.5-fold (0.18 log units) above, and the stated range covers the measured number.
By their numbers in this assay, from the lowest: compounds 1, 3 and 4 (each within the scatter of the next); then compound 2.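

In this assay, methyl in place of hydrogen on this aromatic carbon, ortho to a large group, gives a 3.0-fold lower number from compound 2 to compound 4 (0.48 log units; beyond the scatter). The earlier step from methoxy to hydrogen had shown only one group at this carbon; with methyl in that place there is no change at the digits printed from compound 1 to compound 4 (within the scatter), so the lower number in this pair of compounds does not depend on methoxy, and methyl and methoxy cannot be told apart here. Nothing available explains why either group has this effect on the read-out.

On these data alone, it remains open whether an ethyl chain, a chlorine atom, an amine or a carboxylic acid at this carbon would give the same number as methyl and methoxy. As far as these compounds go, it also remains open whether methyl on another carbon of this ring would produce a comparable step.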